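A few compounds are considered here, and "the series" means these few. Any claim that something is new, unique, unknown or untested is made for them only; others in the source may bear on it.

Of the compounds shown here, three have been tested so far in a functional assay on PC-3 cells (Homo sapiens) for cytotoxicity, read by MTT assay, with a stated time of 72 h (on this read-out higher numbers stand for weaker inhibition and lower numbers for stronger inhibition), and none of them gave a number. Compound 1 `COc1ccc(NC(=O)COC(=O)/C=C/c2cc(OC)c(OCc3ccc(Cl)c(Cl)c3)c(OC)c2)cc1` stopped at the limit of the assay, > 200000 nM. Compound 2 `COCOc1cc(/C=C/C(=O)OCC(=O)Nc2nccs2)ccc1OCc1ccccc1` likewise stopped at the limit, > 200000 nM. Compound 3 `O=C(COC(=O)/C=C/c1ccc(O)c(O)c1)NN1CCOCC1` reached the same limit, > 200000 nM. Compound 2 therefore stands exactly where every measured compound stands, at the limit where all three values sit (the limit of > 200000 nM in this assay, at which 3 of the 3 values shown sit), and nothing separates it from the others.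

Compound 4 `COCOc1cc(/C=C/C(=O)OCC(=O)Nc2ccc(OC)cc2)ccc1OCc1ccccc1` differs from compound 2 in one place (4-methoxyphenyl in place of 1,3-thiazol-2-yl on an amide-type nitrogen). Compound 1 carries the same 4-methoxyphenyl group on its amide-type nitrogen, and its result in this assay was the limit as well. For the measured compounds named here, no step between two measured compounds has been observed, so no size of step can be read from the data. In this assay the step is expected to show no change beyond the scatter, a step that the limit leaves unreadable from compound 2 to compound 4, with compound 4 most likely ending at the limit once more. Compound 4 is estimated at 300000 nM, within 100000 nM to 1000000 nM.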

Compound 4, half-maximal inhibitory concentration: > 200000 nM
Compound 4: a limit, no number; the forecaster's own chance of this, stated with the estimate: 85%; the middle value lies beyond the limit too.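

Compound 4 stops at a limit of the assay, which is > 200000 nM and not a number. Compound 2 sits at a limit too, so no step can be read between compound 2 and compound 4 in this assay here. The compounds shown leave open which change, if any, would bring a measurable value, for all of them share one limit: the limit of > 200000 nM in this assay, at which 4 of the 4 values shown sit.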